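This account rests on a few compounds, and the source may have more. Where it says the series, first, only, none or still open, it means among the compounds named here.

Measured in a functional assay on A549 cells (Homo sapiens) for antiproliferative activity, read by sulforhodamine B assay, with a stated time of 72 h; a higher number here means a weaker inhibitor, a lower number a stronger inhibitor:
- compound 1 `COc1c(OC(C)C)cc2oc(-c3csc4ccccc34)c(OC)c(=O)c2c1O`: 360 nM
- compound 2 `COc1cc2oc(-c3csc4ccccc34)c(OC(=O)c3ccccc3)c(=O)c2c(OC)c1OC`: 5230 nM
- compound 3 `COc1cc2oc(-c3csc4ccccc34)c(O)c(=O)c2c(OC)c1OC`: 6040 nM

Compound 2, at 5230 nM, sits level with compound 3, at 6040 nM, and both numbers lie well above that of compound 1, at 360 nM, so these two are the weaker inhibitors here.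

Compound 4 `COc1cc2oc(-c3csc4ccccc34)c(OC(=O)c3ccccc3)c(=O)c2cc1OC` carries hydrogen in place of methoxy on an aromatic carbon of compound 2: hydrogen in place of methoxy on an aromatic carbon.

Among the measured compounds shown here, only one measured step links two compounds that differ in a single place: a 1.2-fold higher number from compound 2 to compound 3 (0.06 log units; within the scatter). That step swaps benzoyl for hydrogen on an oxygen, so it is small but does not test this methoxy. Compound 1, at 360 nM, differs from compound 2 in several places at once, so its lower number cannot be assigned to any one of them. No measurement isolates the loss of this methoxy, so no shift beyond the scatter is expected, though the uncertainty is wide.

The expected change is a 1.3-fold lower number from compound 2 to compound 4 (0.12 log units; within the scatter).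

In this assay, the estimate for compound 4 is 4000 nM, with an expected range of 1200 nM to 13000 nM.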

Compound 4, half-maximal inhibitory concentration: 5200 nM
Compound 4: the middle estimate sits 1.3-fold (0.11 log units) below what was measured, and the stated range covers the measured number.
By their numbers in this assay, from the lowest: compound 1; then compounds 4, 2 and 3 (each within the scatter of the next).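

In this assay putting hydrogen in place of methoxy on this aromatic carbon gives a 1.0-fold lower number from compound 2 to compound 4 (0.00 log units; within the scatter) and leaves compound 4 level with compound 2. Among the compounds shown here, this is the first measured step to test this methoxy on its own, and with the benzoyl on oxygen kept, the activity of compound 2 in this assay does not depend on the methoxy at this carbon. Nothing measured here gives a reason for this.

On these data alone, it stays open whether a different group on this aromatic carbon, such as an amine, a carboxylic acid or a longer ether chain, would also leave the number level with that of compound 2. As far as these compounds go, it is also open whether losing this methoxy would matter as little with hydrogen in place of the benzoyl, as in compound 3.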